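Aryl versus alkyl at the chain carbon of the shared core

The compounds below may be only part of what the source reports. "The series", "measured", "known", "first", "only" and "open" are said of these compounds alone.

Two members of the series have been measured in an in vitro functional assay on cells for agonist activity at Bombesin receptor subtype-3 (Homo sapiens), read by luminescence and calcium flux; a lower number here means that less compound is needed, a higher number that more compound is needed for the effect. Compound 1 `COc1ccc(Cc2cnc(CCc3ccc(-c4ccccc4C(=O)O)cc3)[nH]2)cc1` carries a 4-methoxyphenyl group on a saturated chain carbon bound to an aromatic carbon and gives 5360 nM. Compound 2 `CC(C)CCc1cnc(CCc2ccc(-c3ccccc3C(=O)O)cc2)[nH]1` carries isobutyl at that place and gives 119 nM, the lowest of the two numbers; the step of a 45-fold lower number from compound 1 to compound 2 (1.65 log units; beyond the scatter) is the only one available and is large. For the measured compounds named here, compound 3 `Cc1ccc(Cc2cnc(CCc3ccc(-c4ccccc4C(=O)O)cc3)[nH]2)cc1` differs from compound 2 by 4-methylphenyl in place of isobutyl on a saturated chain carbon bound to an aromatic carbon, which reinstates an aryl group like the one in compound 1, with methyl replacing methoxy on it. Going by the values given here, the one step that bears on this change, a 45-fold lower number from compound 1 to compound 2 (1.65 log units; beyond the scatter), runs in the opposite direction, so a large rise in this assay is expected for compound 3. Among the compounds with values here, the methyl for methoxy difference from compound 1 has no measured counterpart, so the full size of that step is not assumed. Within the data shown here, the estimated step of a 25-fold higher number from compound 2 to compound 3 (1.40 log units; beyond the scatter) places compound 3 at 3000 nM, with a range of 700 nM to 12000 nM, the width reflecting the single precedent.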

Compound 3, half-maximal effective concentration: 2660 nM
For compound 3 the middle estimate is 1.1-fold (0.05 log units) above the measured one; the measured number falls inside the stated range.
By their numbers in this assay, from the lowest: compound 2; then compounds 3 and 1 (each within the scatter of the next).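

In this assay, the large gap between alkyl and aryl at this place no longer rests on compound 1 alone: 4-methylphenyl in place of isobutyl gives a 22-fold higher number from compound 2 to compound 3 (1.35 log units; beyond the scatter), so a second aryl group shows the same kind of step. The other new comparison isolates the substituent on that aryl group, and methyl in place of methoxy gives a 2.0-fold lower number from compound 1 to compound 3 (0.30 log units; within the scatter), which leaves these two groups unresolved from each other and shows that, across these three compounds, the large step appears only where isobutyl is exchanged for an aryl group. Nothing available accounts for either step.

Still open, from the compounds shown here alone, is whether the large step follows the aromatic ring itself or the size of the entering group, a question that a saturated ring such as cyclohexyl at the same place could address. Also open, going by these compounds, are how far the chain can vary around isobutyl, for example with a longer chain, and whether an amine or a carboxylic acid on the aryl group would produce a step beyond the scatter.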